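The source may report more compounds than this note shows. Statements on the series, on what has been measured and on what is new or still open speak of the compounds shown alone.

Compound 1 `O=c1ccc2cc(OCc3cc(-c4ccc5ccccc5c4)no3)ccc2o1`, compound 2 `COc1ccc(-n2cc(COc3ccc4oc(=O)ccc4c3)nn2)cc1` and compound 3 `CC(=O)Nc1ccc(-n2cc(COc3ccc4oc(=O)ccc4c3)nn2)cc1` share one core, a coumarin-type fragment carrying a linker to a five-membered aromatic ring; they differ in the aromatic ring attached to that linker. In a functional assay on HCT-116 cells (Homo sapiens) for cytotoxicity, read by MTT assay, with a stated time of 48 h (a higher number here means a weaker inhibitor, a lower number a stronger inhibitor), compound 1 gives 55900 nM. Compound 2 gives 37800 nM in this assay, and since this differs from the number for compound 1 by less than the usual scatter, the two compounds cannot be told apart here. In this assay, among the compounds with values here, compound 3 gives "not determined" (no result reported), so only two numbers are available, and no single change between two measured compounds can be followed.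

Compound 4 `O=c1ccc2cc(OCc3cn(-c4ccccc4[N+](=O)[O-])nn3)ccc2o1` differs from compound 2 in one place: 2-nitrophenyl in place of 4-methoxyphenyl on an aromatic nitrogen. Within the data shown here, with no measured step of this kind to lean on, the expectation for the move from compound 2 to compound 4 is a change of a 1.1-fold higher number from compound 2 to compound 4 (0.02 log units; within the scatter), which is not beyond the scatter in either direction. Compound 4 is therefore estimated to give 40000 nM in this assay, with a likely range from 15000 nM to 100000 nM.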

Compound 4, half-maximal inhibitory concentration: 55800 nM
Compound 4: the middle estimate sits 1.4-fold (0.14 log units) below what was measured; measured number inside the range.
By their numbers in this assay, from the lowest: compounds 2, 4 and 1 (each within the scatter of the next).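

Within the data shown here, replacing 4-methoxyphenyl with 2-nitrophenyl on the aromatic nitrogen gives the first one-place comparison in this assay, with a 1.5-fold higher number from compound 2 to compound 4 (0.17 log units; within the scatter), and this step lies within the scatter. At this position, therefore, the two substituted phenyl groups cannot be told apart in this pair, although one carries a methoxy group and the other a nitro group, so this single exchange does not show the position to be sensitive to that change. Nothing measured here offers an explanation for this result.

From the compounds shown here alone, it remains open whether a simple amine or a carboxylic acid on the phenyl ring, or a longer chain in place of that ring, would give a step beyond the scatter. Going by these compounds, it is also open whether 4-nitrophenyl would read like 2-nitrophenyl.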